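The source may report more compounds than this note shows. Statements on the series, on what has been measured and on what is new or still open speak of the compounds shown alone.

In a functional assay on A549 cells (Homo sapiens) for cytotoxicity, read by MTT assay, with a stated time of 72 h (on this read-out higher numbers stand for weaker inhibition and lower numbers for stronger inhibition), compound 1 `COc1cc(/C=C2\CNC/C(=C\c3cc(OC)c(OC)c(OC)c3)C2=O)cc(OC)c1OC` gives 1200 nM and compound 2 `COc1cc(/C=C2\CN(C(=O)C(C)C)C/C(=C\c3cc(OC)c(OC)c(OC)c3)C2=O)cc(OC)c1OC` gives 800 nM on the same read-out. These two numbers lie within the scatter of each other (a 1.5-fold lower number from compound 1 to compound 2 (0.18 log units; within the scatter)), so the data do not separate compound 2 from compound 1. Going by the values given here, compound 3 `CCC(=O)N1C/C(=C\c2cc(OC)c(OC)c(OC)c2)C(=O)/C(=C/c2cc(OC)c(OC)c(OC)c2)C1` has no measurement yet. It differs from compound 2 by hydrogen in place of methyl on a saturated chain carbon bound to a carbonyl carbon and a saturated chain carbon in one place, with hydrogen in place of methyl on a saturated chain carbon bound to a carbonyl carbon and a saturated chain carbon, which turns isopropylcarbonyl into propanoyl. Among the compounds with values here, only one measured step bears on this change. Going from compound 1 to compound 2, the whole isopropylcarbonyl group took the place of hydrogen on an amine nitrogen in a ring, and that step stayed within the scatter (a 1.5-fold lower number from compound 1 to compound 2 (0.18 log units; within the scatter)). Within the data shown here, no measured pair tests the methyl itself. Removing it is therefore expected to leave the number within the scatter, in no clear direction, and the estimated step is small (a 1.1-fold higher number from compound 2 to compound 3 (0.03 log units; within the scatter)). Compound 3 is expected at 850 nM (estimated range 400 nM to 1800 nM).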

Compound 3, half-maximal inhibitory concentration: 800 nM
Compound 3: the middle estimate sits 1.1-fold (0.03 log units) above what was measured; the measured number falls inside the stated range.
By their numbers in this assay, from the lowest: compounds 2, 3 and 1 (each within the scatter of the next).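

Going by these compounds alone, the pair compound 2 and compound 3 tests the methyl itself, which no earlier pair did: in this assay, isopropylcarbonyl going to propanoyl, with hydrogen in place of methyl on a saturated chain carbon bound to a carbonyl carbon and a saturated chain carbon, gives no change at the digits printed from compound 2 to compound 3 (within the scatter) and so leaves no measurable mark on this read-out. A second group on the amine nitrogen in a ring can now also be set against hydrogen there, and propanoyl gives a 1.5-fold lower number from compound 1 to compound 3 (0.18 log units; within the scatter) in a step of the same printed size as the one for isopropylcarbonyl, so neither group is separated from hydrogen at this position. Nothing given here accounts for these readings.

Whether a longer chain, a benzoyl group or a carboxylic acid on that nitrogen would give a step beyond the scatter stays open, since all three compounds shown lie within the scatter of each other. These compounds also leave open whether the same insensitivity to the methyl would hold on any other cell line.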